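The compounds below may be only part of what the source reports. "The series", "measured", "known", "first", "only" and "open" are said of these compounds alone.

Measured so far in a functional assay on HepG2 cells (Homo sapiens) for cytotoxicity, read by MTT assay, with a stated time of 24 h; a higher number here means a weaker inhibitor, a lower number a stronger inhibitor
- compound 1 `Nc1cccn2cc(Cc3ccccc3)c(=O)nc12` gives 131000 nM
- compound 2 `O=c1nc2ccc(Br)cn2cc1Cc1ccccc1` gives > 1000000 nM

For compound 2 the reading > 1000000 nM is a limit of the assay and not a number. Compound 3 `Nc1cc(Br)cn2cc(Cc3ccccc3)c(=O)nc12` has amino in place of hydrogen on an aromatic carbon of compound 2 (amino in place of hydrogen on an aromatic carbon) and keeps the bromo group. Compound 1 carries the amino group without the bromo group and gives 131000 nM and on that value a step to a lower number in this assay is expected, toward a stronger inhibitor. The estimated step (an at least 5.0-fold lower number from compound 2 to compound 3 (0.69 log units; beyond the scatter)) remains rough. Compound 3 is expected at 200000 nM with an estimated range of 60000 nM to 700000 nM overall.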

Compound 3, half-maximal inhibitory concentration: > 1000000 nM
Compound 3: only a limit was reported; the forecaster's own chance of this, stated with the estimate: 20%; at least 5.0-fold (0.69 log units) between middle value and limit.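

With the amino group kept, the added bromo group gives an at least 7.6-fold higher number from compound 1 to compound 3 (0.88 log units; beyond the scatter) in this assay. Compound 3 reads > 1000000 nM, which is a limit of the assay and not a number, so amino on this aromatic carbon does not bring the brominated core to a measurable value. The step for adding amino cannot be read because the reading on each side of it is a limit: the limit of > 1000000 nM in this assay, at which 2 of the 3 values shown sit.

Going by these compounds, whether chloro or methyl in place of the bromo group would give a measurable value stays open. On these data alone, how far the true values of compound 2 and compound 3 lie beyond the limit also stays open.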